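The compounds below may be only part of what the source reports. "The series", "measured", "known", "first", "only" and "open" are said of these compounds alone.

Working notes on the series. Of the compounds shown here, three have been measured. Compound 1 `O=C(c1nc2cc(Cl)ccc2s1)N1CCN(c2cnccn2)CC1` and compound 2 `O=C(c1nc2cc(C(F)(F)F)ccc2s1)N1CCN(c2cnccn2)CC1` differ only by trifluoromethyl in place of chloro on an aromatic carbon; compound 3 `O=C(c1nc2ccccc2s1)N1CCN(c2ccccc2)CC1` differs from both in two places. In an ADME assay on RAW264.7 cells (Mus musculus) for cytotoxicity, read by MTT assay, with a stated time of 72 h, tested at 50 ug/mL (a lower number here means less inhibition, a higher number more inhibition at the concentration tested (going by the name of the read-out)), compound 1 gives 54.9%, compound 2 gives 28.1% and compound 3 gives 67.2%. Compound 2 thus stands lowest of the three: the gap to compound 1 and the larger gap to compound 3 both lie beyond the scatter.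

Going by the values given here, the only single-point step measured so far is a number 26.8 percentage points lower from compound 1 to compound 2 (beyond the scatter). It concerns the group on the aromatic carbon, not the amine nitrogen, so it bears on the next step only indirectly.

Compound 4 `COc1ccc(N2CCN(C(=O)c3nc4cc(C(F)(F)F)ccc4s3)CC2)cc1` has not been measured. Relative to compound 2 the change is 4-methoxyphenyl in place of pyrazin-2-yl on an amine nitrogen in a ring. Among the compounds with values here, no measured pair differs in this place alone. Compound 3, which carries a carbon-only aromatic ring on the same ring nitrogen, gives the highest number of the three, but it also lacks the trifluoromethyl, so it is a hint rather than a step.

On that hint a moderate rise is expected, a number 16.9 percentage points higher from compound 2 to compound 4 (beyond the scatter). For compound 4 the estimate is 45%, within 25% to 65%.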

Compound 4, a percentage reported as inhibition, at one concentration (the size of the read-out at that concentration, not a potency): 19.4%
Compound 4: the middle estimate sits 25.6 percentage points above what was measured; measured number outside the range, below it.
By their numbers in this assay, from the lowest: compounds 4 and 2 (each within the scatter of the next); then compound 1; then compound 3.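

In this assay, the exchange of pyrazin-2-yl for 4-methoxyphenyl on the amine nitrogen in a ring, with the trifluoromethyl kept in place, gives a number 8.7 percentage points lower from compound 2 to compound 4 (within the scatter). Going by these compounds alone, this is the first direct reading at this position, and it does not separate the two compounds: on this core, a six-membered aromatic ring of carbon only bearing a methoxy group and a six-membered aromatic ring with 2 hetero atoms cannot be told apart in this read-out, so the hint drawn from compound 3 finds no support in this single step. No measurement at hand bears on why this change makes so little difference in the read-out.

On these data alone, whether the same exchange is equally silent with chloro on the aromatic carbon, as in compound 1, remains open, and so does what part of the number of compound 3 belongs to the amine nitrogen's substituent and what part to the missing trifluoromethyl. Also open, as far as these compounds go, is whether a non-aromatic group on the same nitrogen, such as cyclohexyl, or a benzyl group with its extra carbon, would leave the read-out within the scatter of compound 2 or move it clearly.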